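Capping the other hydroxy of compound 1

A few compounds are considered here, and "the series" means these few. Any claim that something is new, unique, unknown or untested is made for them only; others in the source may bear on it.

Among the measured compounds shown here, in an ADME assay on HEK293 cells (Homo sapiens) for inhibition, read by MTT assay, with a stated time of 2 days (a higher number here means a weaker inhibitor, a lower number a stronger inhibitor), compound 1 `Oc1ccc(/C=C/c2cccc(O)c2)cc1` gives 1.1 ug/mL as the lowest of the three numbers measured so far, which makes it the strongest inhibitor among them. Compound 2 `Nc1ccc(/C=C/c2cccc(O)c2)cc1` comes in at 25 ug/mL and compound 3 `COc1ccc(/C=C/c2cccc(O)c2)cc1` at 24 ug/mL and a 1.0-fold lower number from compound 2 to compound 3 (0.02 log units; within the scatter) is no real difference.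

Compound 4 `COc1cccc(/C=C/c2ccc(O)cc2)c1` has not been measured yet. It differs from compound 1 in one place (methyl in place of hydrogen on an oxygen on an aromatic ring) with methyl in place of hydrogen on an oxygen on an aromatic ring, so a hydroxy becomes a methoxy. The closest measured change is the same swap made on the other hydroxy, which gave a 22-fold higher number from compound 1 to compound 3 (1.34 log units; beyond the scatter) as a large rise. Amino in place of hydroxy at that same spot gave a 23-fold higher number from compound 1 to compound 2 (1.36 log units; beyond the scatter) as a rise of similar size. For the measured compounds named here, both steps alter the hydroxy that compound 4 keeps, and no measured compound alters the hydroxy that compound 4 caps, so these precedents carry over only loosely. A rise is still expected, though a smaller one. The step expected is a 5.5-fold higher number from compound 1 to compound 4 (0.74 log units; beyond the scatter) and this would fall short of those two. In this assay compound 4 is estimated at 6 ug/mL with 1.5 ug/mL and 25 ug/mL as the expected ends of the range.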

Compound 4, half-maximal inhibitory concentration: 24 ug/mL
For compound 4 the middle estimate is 4.0-fold (0.60 log units) below the measured one, and the stated range covers the measured number.
By their numbers in this assay, from the lowest: compound 1; then compounds 3, 4 and 2 (each within the scatter of the next).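

This position turns out to matter as much as the other one: in this assay, methyl in place of hydrogen on this oxygen gives a 22-fold higher number from compound 1 to compound 4 (1.34 log units; beyond the scatter), and the same change on the other hydroxy gives a 22-fold higher number from compound 1 to compound 3 (1.34 log units; beyond the scatter), a step of the same printed size. The earlier compounds only showed changes at the hydroxy that compound 4 keeps, so a high number might have belonged to that site alone, but among these four compounds, capping either hydroxy moves the number by a large step, and compound 1, with both hydroxy groups free, stays the strongest inhibitor. No measurement at hand explains why so small an addition on either oxygen has so large an effect.

The compounds shown leave open whether it is the hydrogen on this oxygen that counts, or simply the presence of a methyl, since an amine or a fluorine at this spot would help to separate the two. They also leave open how a longer chain such as ethoxy would read here, and what happens when both hydroxy groups carry a methyl.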